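The source may hold more compounds than are shown below. What is called first, only, known or untested is meant among the compounds shown, and "the series" means these compounds.

Compound 1 `COc1nc(C2CCOCC2)ccc1[C@@H](c1ccccc1)[C@@](O)(CCN(C)C)c1cccc2ccccc12` is the reference point of this small set. In a toxicity assay on HeLa cells (Homo sapiens) for cytotoxicity (a higher number here means that more compound is tolerated, a lower number that less compound is tolerated), compound 1 gives 22.5 ug/mL. Compound 2 `COc1nc(-c2ccc(C#N)cc2)ccc1[C@@H](c1ccccc1)[C@@](O)(CCN(C)C)c1cccc2ccccc12` carries a 4-cyanophenyl where compound 1 carries an oxan-4-yl. For compound 2 this assay reports > 64 ug/mL, which is a limit of the assay and not a number. The step of an at least 2.8-fold higher number from compound 1 to compound 2 (0.45 log units; beyond the scatter) is accordingly a lower bound, resting on (the limit of > 64 ug/mL in this assay, at which 1 of the 3 values shown sits). Compound 3 `COc1nc(-c2ccccc2F)ccc1[C@@H](c1ccccc1)[C@@](O)(CCN(C)C)c1cccc2ccccc12` is a third variant at that place; for compound 3 this assay shows "nd" (no result reported), so no result is available. Compound 2 therefore stands at the upper edge of what this assay can report, and nothing more precise is known about it.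

Compound 4 `COc1nc(-c2ccsc2)ccc1[C@@H](c1ccccc1)[C@@](O)(CCN(C)C)c1cccc2ccccc12` has not yet been measured in this assay. It differs from compound 2 by thiophen-3-yl in place of 4-cyanophenyl on an aromatic carbon. Only the measured step from compound 1 to compound 2 touches that place, and it shows that swapping the group there can shift the number at least modestly. The swap to thiophen-3-yl is expected to give a step of an at least 1.4-fold lower number from compound 2 to compound 4 (0.15 log units; that floor lies within the scatter), a mild move downward that may still reach the assay limit. Compound 4 is estimated at 45 ug/mL, within 20 ug/mL to 100 ug/mL.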

Compound 4, half-maximal cytotoxic concentration: > 64 ug/mL
Compound 4: no number, only a limit (the forecaster's own chance of this, stated with the estimate: 40%); middle value at least 1.4-fold (0.15 log units) from the limit.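

In this assay compound 4 gives > 64 ug/mL, which is a limit of the assay and not a number. Replacing oxan-4-yl with thiophen-3-yl gives an at least 2.8-fold higher number from compound 1 to compound 4 (0.45 log units; beyond the scatter), a lower bound, so the shift first seen with 4-cyanophenyl is not confined to that one group and also appears with a five-membered aromatic ring containing sulfur. The step between compound 2 and compound 4 cannot be read because both compounds rest on the same limit: the limit of > 64 ug/mL in this assay, at which 2 of the 4 values shown sit.

Compound 3 has no result, so it adds nothing on whether further aromatic groups at this place follow compound 2 and compound 4. As far as these compounds go, how a basic amine such as piperidin-4-yl or a carboxylic acid at this place would read also remains open.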